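The source may hold more compounds than are shown below. What is called first, only, known or untested is meant among the compounds shown, and "the series" means these compounds.

Of the compounds shown here, three built on a shared core have been measured. In a functional assay on HCT-15 cells (Homo sapiens) for inhibition, read by sulforhodamine B assay, with a stated time of 48 h (on this read-out higher numbers stand for weaker inhibition of growth and lower numbers for stronger inhibition of growth), compound 1 `COc1cccc(Oc2ccnc3ccsc23)c1` gives 390 nM, the lowest of the three numbers. Compound 2 `COc1ccccc1Oc1ccnc2ccsc12` has the same atoms as compound 1, joined differently; the difference between the two cores is not broken down here. In this assay compound 2 gives 91200 nM, and compound 3 `Fc1ccccc1Oc1ccnc2ccsc12` gives 97200 nM. The change from compound 2 to compound 3 is fluoro in place of methoxy on an aromatic carbon and produced a 1.1-fold higher number from compound 2 to compound 3 (0.03 log units; within the scatter).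

Compound 4 `Fc1cccc(Oc2ccnc3ccsc23)c1` awaits measurement. It differs from compound 1 by fluoro in place of methoxy on an aromatic carbon, the same kind of change, but made meta to a large group rather than ortho to a large group. For compound 4 the expected step is a 1.3-fold higher number from compound 1 to compound 4 (0.11 log units; within the scatter), resting on the earlier pair because a 1.1-fold higher number from compound 2 to compound 3 (0.03 log units; within the scatter) lay within the scatter. Compound 4 is therefore estimated at 500 nM, between 150 nM and 2500 nM.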

Compound 4, concentration for 50% growth inhibition: 103000 nM
For compound 4 the middle estimate is 210-fold (2.31 log units) below the measured one; the measured number lies above the stated range.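

In this assay, fluoro in place of methoxy gave a 260-fold higher number from compound 1 to compound 4 (2.42 log units; beyond the scatter), and the same change had a very different size on the other core: the same change on two cores in this assay, a 1.1-fold higher number (0.03 log units; within the scatter) from compound 2 to compound 3 and a 260-fold higher number (2.42 log units; beyond the scatter) from compound 1 to compound 4, 250-fold (2.39 log units) apart, beyond the scatter of two such steps. In this series, then, a step read on one core cannot simply be carried over to the other. Going by these compounds alone, with only one pair on each core, this does not show why the two steps differ, nor whether the gap would hold for any other replacement of methoxy.

The compounds shown leave open whether the methoxy of compound 1 is unusual in this place. An amine, a hydroxyl or a chloro there could give a number near that of compound 1 or near that of compound 4.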